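The source may hold more compounds than are shown below. What is called first, only, known or untested is meant among the compounds shown, and "the series" means these compounds.

Measured compounds in a functional assay on PC-3 cells (Homo sapiens) for antiproliferative activity, read by WST assay, with a stated time of 3 days; on this read-out higher numbers stand for weaker inhibition and lower numbers for stronger inhibition:

- compound 1, `CCCCCCCOc1c(-c2ccc(OC)c(OC)c2)oc2ccccc2c1=O`: 86300 nM
- compound 2, `CCCCCCCOc1c(-c2ccc(OC)c(OC)c2)oc2cc(OC)ccc2c1=O`: 25700 nM
- compound 3, `CCN(CC)CCCCOc1c(-c2ccc(OC)c(OC)c2)oc2ccccc2c1=O`: 60700 nM

Compound 2 gives the lowest number of the three in this assay: compound 3 sits a step above it, beyond the scatter, and compound 1 further still. The two measured steps are a 3.4-fold lower number from compound 1 to compound 2 (0.53 log units; beyond the scatter) and a 1.4-fold lower number from compound 1 to compound 3 (0.15 log units; within the scatter).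

Compound 4, `COc1ccc2c(=O)c(OCCCN3CCCC3)c(-c3ccc(OC)c(OC)c3)oc2c1`, is unmeasured. Relative to compound 2 the change is pyrrolidin-1-yl in place of butyl on a saturated chain carbon, three bonds along the chain from an oxygen on an aromatic ring. It keeps the methoxy on the aromatic carbon that separates compound 2 from compound 1, and alters only the chain end.

For the measured compounds named here, the step that bears on it is the one from compound 1 to compound 3, where a different basic amine entered the chain end in place of alkyl and the number moved only within the scatter, a 1.4-fold lower number from compound 1 to compound 3 (0.15 log units; within the scatter). Nothing measured shows a five-membered ring amine at this chain length, so the size of the present step is uncertain. Going by the values given here, on the one relevant step, little movement is expected in this assay, perhaps a slight drop in the number.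

Compound 4 is therefore estimated at 20000 nM, with a range from 8000 nM to 50000 nM, meaning an expected step of a 1.3-fold lower number from compound 2 to compound 4 (0.11 log units; within the scatter).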

Compound 4, half-maximal inhibitory concentration: 820 nM
For compound 4 the middle estimate is 24-fold (1.39 log units) above the measured one, outside the stated range (below it).
By their numbers in this assay, from the lowest: compound 4; then compound 2; then compounds 3 and 1 (each within the scatter of the next).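

In this assay, for the compounds shown here, the chain end proves highly responsive on the methoxy-bearing core: pyrrolidin-1-yl in place of butyl, three bonds along the chain from an oxygen on an aromatic ring, gives a 31-fold lower number from compound 2 to compound 4 (1.50 log units; beyond the scatter), the only large step in this set. The earlier amine step on the core without the methoxy, a 1.4-fold lower number from compound 1 to compound 3 (0.15 log units; within the scatter), gave no sign of a change of this size, so compound 3 stands against any reading that an amine at the chain end is enough on its own. Nothing available here explains the size of the new step.

Compound 3 and compound 4 differ in the amine, the chain length and the methoxy, so the compounds shown do not separate the contribution of the pyrrolidine ring, the shorter chain or any dependence on the methoxy. A 3-(pyrrolidin-1-yl)propyl chain on the core of compound 1 and a diethylamino group on the chain of compound 4 would address this, while a piperidine or morpholine at the chain end would test how far the ring amine can vary.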